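The source may hold more compounds than are shown below. What is called first, only, known or untested is meant among the compounds shown, and "the series" means these compounds.

The measured compounds:
compound 1, `Cc1cccc(-n2cc(COc3cccc(NC(=O)Nc4ccc(Cl)c(C(F)(F)F)c4)c3)nn2)c1`, 7270 nM
compound 2, `O=C(Nc1cccc(OCc2cn(-c3ccccc3Cl)nn2)c1)Nc1ccc(Cl)c(C(F)(F)F)c1`, 1960 nM
compound 3, `O=C(Nc1cccc(OCc2cn(-c3ccc(Cl)cc3)nn2)c1)Nc1ccc(Cl)c(C(F)(F)F)c1`, 2490 nM

In a functional assay on HepG2 cells (Homo sapiens) for inhibition, read by MTT assay, with a stated time of 72 h (on this read-out lower numbers stand for stronger inhibition and higher numbers for weaker inhibition), compound 3 gives 2490 nM, the second highest of the three numbers. Its nearest neighbour is compound 2, which gives 1960 nM. The difference is a 1.3-fold higher number from compound 2 to compound 3 (0.10 log units; within the scatter). The furthest is compound 1, with a 2.9-fold lower number from compound 1 to compound 3 (0.47 log units; beyond the scatter).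

Compound 4, `O=C(Nc1cccc(OCc2cn(-c3cccc(I)c3)nn2)c1)Nc1ccc(Cl)c(C(F)(F)F)c1`, differs from compound 3 by 3-iodophenyl in place of 4-chlorophenyl on an aromatic nitrogen. For the measured compounds named here, two measured steps bear on this position: a 3.7-fold lower number from compound 1 to compound 2 (0.57 log units; beyond the scatter) and a 2.9-fold lower number from compound 1 to compound 3 (0.47 log units; beyond the scatter), both modest lowerings when a chlorophenyl replaced 3-methylphenyl. The step of a 1.3-fold higher number from compound 2 to compound 3 (0.10 log units; within the scatter) shows that moving the chlorine between its two measured positions made no difference beyond the scatter. Going by the values given here, no measured step exchanges chlorine for iodine, and the only other 3-substituted phenyl, in compound 1, gave the highest number. Compound 4 is therefore expected to show no step beyond the scatter, estimated as a 1.0-fold higher number from compound 3 to compound 4 (0.00 log units; within the scatter). The estimate for compound 4 in this assay is 2500 nM, expected to lie between 1000 nM and 6500 nM.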

Compound 4, half-maximal inhibitory concentration: 4780 nM
Compound 4: middle estimate off by 1.9-fold (0.28 log units), on the low side, within the range that was stated.
By their numbers in this assay, from the lowest: compounds 2, 3, 4 and 1 (each within the scatter of the next, the first and the last beyond it).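

In this assay the exchange of 4-chlorophenyl for 3-iodophenyl gives a 1.9-fold higher number from compound 3 to compound 4 (0.28 log units; within the scatter), so a change of both the halogen and its place on the ring does not separate this pair. Set against 2-chlorophenyl, however, 3-iodophenyl gives a 2.4-fold higher number from compound 2 to compound 4 (0.39 log units; beyond the scatter), the first step between halogen-bearing rings at this position to clear the scatter. Iodo in place of methyl gives a 1.5-fold lower number from compound 1 to compound 4 (0.18 log units; within the scatter), so compound 1 and compound 4, the two compounds with a group at the 3-position of this ring, are not separated from each other.

Nothing shown here accounts for these differences. The compounds shown leave open how 3-chlorophenyl, which would separate the effect of the halogen from that of its place, or a phenyl ring carrying an amine or a carboxylic acid would behave at this position.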